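Dichloro for bromo on the aryl arm: cytotoxicity outlook

The source may report more compounds than this note shows. Statements on the series, on what has been measured and on what is new or still open speak of the compounds shown alone.

Compound 1 `COc1cccc(/C=C2\CCC/C(=C\c3ccccc3Cl)C2=O)c1OC` — 44200 nM
Compound 2 `COc1cccc(/C=C2\CCC/C(=C\c3cccc(Br)c3)C2=O)c1OC` — 23900 nM
Compound 3 `COc1cccc(/C=C2\CCC/C(=C\c3ccc(O)cc3)C2=O)c1OC` — a limit only

In an ADME assay on NHDF cells (Homo sapiens) for cytotoxicity, read by MTT assay, with a stated time of 72 h (a lower number here means a stronger inhibitor, a higher number a weaker inhibitor), compound 2 gives 23900 nM, the lowest of the two numbers shown. Its nearest neighbour is compound 1, and the step of a 1.8-fold lower number from compound 1 to compound 2 (0.27 log units; within the scatter) stays within the scatter. For compound 3 the assay reports only a limit, > 50000 nM, at which (the limit of > 50000 nM in this assay, at which 1 of the 3 values shown sits). Among the measured compounds shown here, the step of an at least 2.0-fold higher number from compound 2 to compound 3 (0.32 log units; beyond the scatter) is the one change beyond the scatter in this assay.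

Compound 4 `COc1cccc(/C=C2\CCC/C(=C\c3ccc(Cl)c(Cl)c3)C2=O)c1OC` differs from compound 2 by 3,4-dichlorophenyl in place of 3-bromophenyl on a double-bonded chain carbon bound to a double-bonded ring carbon. The step that bears most on it is the exchange of one halogen-bearing aryl for another in compound 1 and compound 2, which gave a 1.8-fold lower number from compound 1 to compound 2 (0.27 log units; within the scatter), a move inside the scatter. The step to compound 3 involves a 4-hydroxyphenyl and is less relevant. Compound 4 is therefore expected to stay near compound 2, with a 1.2-fold lower number from compound 2 to compound 4 (0.08 log units; within the scatter) not beyond the scatter. The estimate for compound 4 in this assay is 20000 nM, between 9000 nM and 45000 nM.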

Compound 4, half-maximal inhibitory concentration: 25500 nM
The estimate for compound 4 lay 1.3-fold (0.11 log units) below the measured number, within the range that was stated.
By their numbers in this assay, from the lowest: compounds 2, 4 and 1 (each within the scatter of the next). At a limit, above all of these: compound 3.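

At this place, on a double-bonded chain carbon bound to a double-bonded ring carbon, the second halogen and the change from bromine to chlorine left no readable mark in this assay: the steps are a 1.1-fold higher number from compound 2 to compound 4 (0.03 log units; within the scatter) and a 1.7-fold lower number from compound 1 to compound 4 (0.24 log units; within the scatter), so these three halogen-bearing arms cannot be told apart here. Against the 4-hydroxyphenyl arm, the new compound gives an at least 1.9-fold lower number from compound 3 to compound 4 (0.29 log units; that floor lies within the scatter), and this floor does not clear the scatter. Compound 3 is known only as a limit: the limit of > 50000 nM in this assay, at which 1 of the 4 values shown sits.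

From the compounds shown here alone, what an amine or a carboxylic acid on this aryl arm would do to the number remains open. So does the true value of compound 3, and with it the full size of the gap between the hydroxyl-bearing arm and the halogen-bearing arms.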